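From 4-chlorophenyl to 2-bromophenyl in one swap

The compounds below may be only part of what the source reports. "The series", "measured", "known", "first", "only" and "open" are said of these compounds alone.

Compound 1 `Cc1cc(=O)c2c(O)c(CN3CCC(Cc4ccccc4)CC3)c(O)c([C@H]3CCN(C)C[C@H]3O)c2o1` gives 28%
Compound 2 `CCOC(=O)N1CCN(Cc2c(O)c([C@H]3CCN(C)C[C@H]3O)c3oc(C)cc(=O)c3c2O)CC1` gives 16%
Compound 3 `Cc1oc2c([C@H]3CCN(C)C[C@H]3O)c(O)cc(O)c2c(=O)c1C(O)c1ccc(Cl)cc1` gives 2%

In a functional assay on HL-60 cells (Homo sapiens) for inhibition, read by MTT assay, with a stated time of 48 h, tested at 10 uM (on this read-out lower numbers stand for less inhibition of growth and higher numbers for more inhibition of growth at the one concentration tested), compound 3 (2%) stands lowest of the three, and its gaps to compound 2 and compound 1 both lie beyond the scatter. Compound 4 `Cc1oc2c([C@H]3CCN(C)C[C@H]3O)c(O)cc(O)c2c(=O)c1C(O)c1ccccc1Br` differs from it in one group (2-bromophenyl in place of 4-chlorophenyl on a saturated chain carbon bound to an aromatic carbon and an oxygen on a saturated carbon), with 2-bromophenyl in place of 4-chlorophenyl on a saturated chain carbon bound to an aromatic carbon and an oxygen on a saturated carbon. For the measured compounds named here, no measured pair shows such a swap, so the expectation rests on compound 3 (2%) alone. The expected step (a number 3 percentage points higher from compound 3 to compound 4 (within the scatter)) in this assay is estimated to stay within the scatter, with no firm direction. For compound 4 the expected value is 5% (estimated range 0% to 16%).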

Compound 4, percent growth inhibition at one concentration: 52%
For compound 4 the middle estimate is 47 percentage points below the measured one; the measured number lies above the stated range.
By their numbers in this assay, from the lowest: compound 3; then compound 2; then compound 1; then compound 4.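

In this assay, replacing 4-chlorophenyl with 2-bromophenyl on the saturated chain carbon gives a number 50 percentage points higher from compound 3 to compound 4 (beyond the scatter), showing that this one group can strongly change the read-out. The step comes with no change in the heavy-atom, donor, acceptor or charge counts of the group. Nothing available bears on why the number rises.

The halogen and its place on the phenyl ring change together, so the compounds shown do not separate the two. On these data alone, how an unsubstituted phenyl or a pyridine ring would read here also stays open.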